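The compounds below may be only part of what the source reports. "The series", "measured", "known", "first", "only" and "open" are said of these compounds alone.

Working notes, permeability series.

Compound 1 `NC(=O)[C@@H](CCC(F)(F)F)N(CC12CC(c3ncon3)(C1)C2)S(=O)(=O)c1ccc(Cl)cc1` is the reference. In an ADME assay on MDCKII-LE cells (Canis lupus familiaris) for permeability (a lower number here means that the compound crosses the layer more slowly, a higher number that the compound crosses the layer faster), compound 1 gives 19.3 10^-6 cm/s, the lowest of the three numbers shown, though its steps to both neighbours stay within the scatter: compound 2 `C[C@]1(C#N)C[C@H](CN([C@H](CCC(F)(F)F)C(N)=O)S(=O)(=O)c2ccc(Cl)cc2)C1` gives 21.8 10^-6 cm/s and compound 3 `N#CC1(CN([C@H](CCC(F)(F)F)C(N)=O)S(=O)(=O)c2ccc(Cl)cc2)CC1` gives 29.9 10^-6 cm/s. The steps are a 1.1-fold higher number from compound 1 to compound 2 (0.05 log units; within the scatter), a 1.5-fold higher number from compound 1 to compound 3 (0.19 log units; within the scatter) and a 1.4-fold higher number from compound 2 to compound 3 (0.14 log units; within the scatter); none of the three ring swaps on the saturated chain carbon bound to the sulfonamide nitrogen moves the read-out beyond the scatter.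

Compound 4 `NC(=O)[C@@H](CCC(F)(F)F)N(C[C@H]1C[C@@H](c2ncon2)C1)S(=O)(=O)c1ccc(Cl)cc1` differs from compound 1 only at that same position: a group of 9 heavy atoms (6 carbon, 2 nitrogen, 1 oxygen; one four-membered non-aromatic ring of carbon only, one five-membered aromatic ring with 3 hetero atoms) in place of a group of 10 heavy atoms (7 carbon, 2 nitrogen, 1 oxygen; 2 four-membered non-aromatic rings of carbon only, one five-membered aromatic ring with 3 hetero atoms), on a saturated chain carbon bound to a sulfonamide nitrogen. The measured steps that bear on this are those from compound 1 to compound 2 and compound 3, both within the scatter, and the change here is smaller than either, since the oxadiazole and one four-membered ring are retained. No step beyond the scatter is therefore expected in this assay, in either direction. Compound 4 is estimated to give 18 10^-6 cm/s, with a range of 10 10^-6 cm/s to 32 10^-6 cm/s, meaning an expected step of a 1.1-fold lower number from compound 1 to compound 4 (0.03 log units; within the scatter).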

Compound 4, apparent permeability: 14.1 10^-6 cm/s
Compound 4: the middle estimate sits 1.3-fold (0.11 log units) above what was measured; low and high end bracket the measured number.
By their numbers in this assay, from the lowest: compounds 4, 1, 2 and 3 (each within the scatter of the next, the first and the last beyond it).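

Removing one four-membered ring at this position while keeping the oxadiazole leaves compound 4 within the scatter of the bridged reference, with a 1.4-fold lower number from compound 1 to compound 4 (0.14 log units; within the scatter) as the step, and exchanging the cyclobutyl substituents also stays within it, with a 1.5-fold lower number from compound 2 to compound 4 (0.19 log units; within the scatter) as the step. The position can nevertheless separate two of its members in this assay, since a 2.1-fold lower number from compound 3 to compound 4 (0.33 log units; beyond the scatter) is a modest step and the first one here printed as beyond the scatter. Nothing measured here speaks to what lies behind these steps.

From the compounds shown here alone, the step between compound 3 and compound 4 changes the ring and the end group together, so the share of each stays open. The compounds shown carry only nitrile and 1,2,4-oxadiazole end groups here, leaving open how a primary amine or a carboxylic acid would read in this assay at this position.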